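Carboxybenzyl in place of imidazolylmethyl on the shared core

The source may report more compounds than this note shows. Statements on the series, on what has been measured and on what is new or still open speak of the compounds shown alone.

Compound 3 `Clc1cc(Cl)cc(CO[C@H]2CCCN(Cc3ncc[nH]3)[C@H]2c2ccccc2)c1` stands at the low end of the numbers gathered so far in an assay on isolated protein for activation of cGMP-dependent protein kinase 1 (Homo sapiens), read by ADP-Glo, with stated times of 120 min and 40 min (a lower number here means that less compound is needed, a higher number that more compound is needed for the effect), where compound 3 gives 47000 nM. Its nearest neighbour is compound 2 `COc1cc(C(=O)O)ccc1CN1CCC[C@H](OCc2cc(Cl)cc(Cl)c2)[C@@H]1c1ccccc1`, which in this assay gives 62000 nM; the two differ by a 1.3-fold lower number from compound 2 to compound 3 (0.12 log units; within the scatter), a gap inside the scatter. Compound 1 `CN1CCC[C@H](OCc2cc(Cl)cc(Cl)c2)[C@@H]1c1ccccc1` carries only hydrogen at the amine nitrogen; for compound 1 the reading in this assay is a limit, > 200000 nM, as noted in the limit of > 200000 nM in this assay, at which 1 of the 3 values shown sits. Both substituted compounds move away from that limit: an at least 3.2-fold lower number from compound 1 to compound 2 (0.50 log units; beyond the scatter) and an at least 4.2-fold lower number from compound 1 to compound 3 (0.62 log units; beyond the scatter).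

Compound 4 `O=C(O)c1ccc(CN2CCC[C@H](OCc3cc(Cl)cc(Cl)c3)[C@@H]2c2ccccc2)cc1` is the next step: 4-carboxyphenyl in place of 1H-imidazol-2-yl on a saturated chain carbon bound to an amine nitrogen in a ring. The incoming group resembles that of compound 2, lacking only the methoxy, and the step from compound 2 to compound 3 lay within the scatter, so no change beyond the scatter is expected from the reverse direction here. For compound 4 the expected value in this assay is 60000 nM, with a range from 25000 nM to 150000 nM. This estimate corresponds to an expected step of a 1.3-fold higher number from compound 3 to compound 4 (0.11 log units; within the scatter).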

Compound 4, half-maximal effective concentration: 76000 nM
Compound 4: the middle estimate sits 1.3-fold (0.10 log units) below what was measured; low and high end bracket the measured number.
By their numbers in this assay, from the lowest: compounds 3, 2 and 4 (each within the scatter of the next). At a limit, above all of these: compound 1.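

At this place, on a saturated chain carbon bound to an amine nitrogen in a ring, two quite different groups read alike in this assay: 4-carboxyphenyl for 1H-imidazol-2-yl gives a 1.6-fold higher number from compound 3 to compound 4 (0.21 log units; within the scatter). Hydrogen in place of methoxy on an aromatic carbon also leaves the reading within the scatter, with a 1.2-fold higher number from compound 2 to compound 4 (0.09 log units; within the scatter), so the methoxy of compound 2 is not required for a reading in this range. The 4-carboxybenzyl group alone still gives an at least 2.6-fold lower number from compound 1 to compound 4 (0.42 log units; beyond the scatter), and this step is only a bound, as compound 1 stands at a limit: the limit of > 200000 nM in this assay, at which 1 of the 4 values shown sits.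

Open, on these data alone, is how a plain benzyl, or an amide or an ester in place of the carboxylic acid, would read at this place. Also open, as far as these compounds go, is whether a longer chain between the amine nitrogen and the carboxylic acid would move the number beyond the scatter.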